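A few compounds are considered here, and "the series" means these few. Any claim that something is new, unique, unknown or untested is made for them only; others in the source may bear on it.

The series shares one core, seen in compound 1 `COc1cc(/C=C/c2nc(N(C)C)c3sccc3n2)cc(OC)c1OC` and compound 2 `COc1cc(/C=C/c2nc(Nc3ccc(O)cc3)c3sccc3n2)cc(OC)c1OC`. In a functional assay on L02 cells (Homo sapiens) for inhibition, read by Griess assay, with stated times of 1 h and 24 h (a higher number here means a weaker inhibitor, a lower number a stronger inhibitor), compound 1 gives only a limit of > 1000000 nM. In this assay compound 2 likewise gives only a limit of > 1000000 nM. The step that the two limits leave unreadable from compound 1 to compound 2 therefore carries no readable size, and compound 2 stands at the limit with no number of its own; both values shown sit at the limit of > 1000000 nM in this assay, at which 2 of the 2 values shown sit. Compound 3 `COc1cc(/C=C/c2nc(N(C)c3ccccc3)c3sccc3n2)cc(OC)c1OC` differs from compound 2 by methyl(phenyl)amino in place of (4-hydroxyphenyl)amino on an aromatic carbon. Among the measured compounds shown here, no measured step with a readable size bears on this change, so nothing in the numbers points either way for it. Compound 3 is expected to sit at a limit as well, the expected step being a number no higher from compound 2 to compound 3 (the limit leaves the size open). Compound 3 is estimated at 1000000 nM in this assay, with a range from 300000 nM to 5000000 nM.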

Compound 3, half-maximal inhibitory concentration: 767000 nM
Compound 3: middle estimate off by 1.3-fold (0.12 log units), on the high side, within the range that was stated.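

In this assay, among the compounds shown here, compound 3 gives 767000 nM, the first value that is a number and not a limit. The other two values remain limits: the limit of > 1000000 nM in this assay, at which 2 of the 3 values shown sit. Methyl(phenyl)amino in place of (4-hydroxyphenyl)amino gives an at least 1.3-fold lower number from compound 2 to compound 3 (0.11 log units; that floor lies within the scatter), and phenyl in place of methyl on the nitrogen gives an at least 1.3-fold lower number from compound 1 to compound 3 (0.11 log units; that floor lies within the scatter), so both changes at this aromatic carbon carry only floors, and neither establishes a real gain in strength.

Still open, from the compounds shown here alone, is whether the methyl on the nitrogen or the loss of the 4-hydroxy group matters more in the change to compound 3, a question that plain phenylamino at this place would separate. Also open, going by these compounds, is how far the number moves with a morpholine ring, a primary amine or a benzylamino group on this carbon.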